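The source may report more compounds than this note shows. Statements on the series, on what has been measured and on what is new or still open speak of the compounds shown alone.

Three compounds have been measured in a functional assay on B16-F10 cells (Mus musculus) for inhibition, read by MTT assay, with a stated time of 72 h; a lower number here means a stronger inhibitor, a higher number a weaker inhibitor:

Compound 1 `COc1ccc(Nc2nc(SCc3cn(CC(=O)NC(=O)Nc4ccccn4)nn3)nc(-c3ccc(C)cc3)c2C#N)cc1` gives 8750 nM.
Compound 2 `Cc1ccc(Nc2nc(SCc3cn(CC(=O)NC(=O)Nc4ccccn4)nn3)nc(-c3ccc(C)cc3)c2C#N)cc1` gives 1010 nM.
Compound 3 `Cc1ccc(-c2nc(SCc3cn(CC(=O)NC(=O)Nc4ccccn4)nn3)nc(Nc3cccc(Cl)c3)c2C#N)cc1` gives 7580 nM.

Compound 2 stands lowest of the three, and both of its neighbours lie beyond the scatter from it: there is an 8.7-fold lower number from compound 1 to compound 2 (0.94 log units; beyond the scatter) and a 7.5-fold higher number from compound 2 to compound 3 (0.88 log units; beyond the scatter). The gap between compound 1 and compound 3, a 1.2-fold lower number from compound 1 to compound 3 (0.06 log units; within the scatter), is within the scatter. All three share one core and differ only in the aryl group carried on the nitrogen.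

Compound 4 `Cc1ccc(Nc2nc(SCc3cn(CC(=O)NC(=O)Nc4ccccn4)nn3)nc(-c3ccccc3)c2C#N)cc1` is not yet measured. It differs from compound 2 in another place: hydrogen in place of methyl on an aromatic carbon. Within the data shown here, this change sits on the aryl group attached to a carbon of the core, which is the same in all three measured compounds, so no measured step bears on it directly. The two steps that are known, from compound 1 to compound 2 and from compound 2 to compound 3, concern a different aryl group and give no guide here. In this assay the expected step from compound 2 to compound 4 is therefore small or none beyond the scatter, a 1.5-fold higher number from compound 2 to compound 4 (0.17 log units; within the scatter). Compound 4 is estimated at 1500 nM, with a range from 500 nM to 4500 nM.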

Compound 4, half-maximal inhibitory concentration: 3300 nM
Beside the measured number, compound 4's estimate is 2.2-fold (0.34 log units) below it; the range from low to high includes it.
By their numbers in this assay, from the lowest: compound 2; then compound 4; then compounds 3 and 1 (each within the scatter of the next).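

Among these compounds, until this result, only the aryl group on the nitrogen had varied, so the second aryl group, attached to a carbon of the shared core, had no reading of its own. In this assay, taking 4-methylphenyl to phenyl gives a 3.3-fold higher number from compound 2 to compound 4 (0.51 log units; beyond the scatter), which shows that this position is not silent: the loss of a single methyl, one heavy atom on a six-membered aromatic ring of carbon only, moves the number beyond the usual scatter, and the methyl-bearing compound 2 is the stronger inhibitor of this pair. Nothing available explains why this methyl matters, so the step stands as an observation without a known cause.

Only hydrogen and methyl are shown at this place, so it remains open whether the trend would continue with a longer chain such as ethyl, or how an amine or a carboxylic acid would behave there. Among the compounds shown here, it is also open whether the same step would appear with 4-methoxyphenyl or 3-chlorophenyl on the nitrogen, since this change is seen only with 4-methylphenyl there.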